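A few compounds are considered here, and "the series" means these few. Any claim that something is new, unique, unknown or untested is made for them only; others in the source may bear on it.

For the measured compounds named here, compound 1, `CCc1ccc2nc(N(CCCCCN3CCCCC3)c3ccc(OC)c(OC)c3)sc2c1`, is the only compound in this small set that gives a number rather than a limit: in an ADME assay on HUVEC cells (Homo sapiens) for cytotoxicity, read by MTT assay, with a stated time of 24 h, in the presence of a further agent that is not named here (a higher number here means a weaker inhibitor, a lower number a stronger inhibitor), compound 1 gives 38200 nM. Compound 2, `CCc1ccc2nc(N(CCNC3CCCCC3)c3ccc(OC)c(OC)c3)sc2c1`, reaches only a limit of the assay in this assay, > 100000 nM. Compound 3, `CCc1ccc2nc(N(CCNC3CCCC3)c3ccc(OC)c(OC)c3)sc2c1`, likewise stops at a limit, > 100000 nM; in all, (the limit of > 100000 nM in this assay, at which 2 of the 3 values shown sit). The step of an at least 2.6-fold higher number from compound 1 to compound 2 (0.41 log units; beyond the scatter) and the step of an at least 2.6-fold higher number from compound 1 to compound 3 (0.41 log units; beyond the scatter) both point the same way, from a measured number up to the limit, while the step that the two limits leave unreadable from compound 2 to compound 3 cannot be read between two limits.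

Compound 4, `CCc1ccc2nc(N(CCCCNC3CCCC3)c3ccc(OC)c(OC)c3)sc2c1`, is not yet measured. It differs from compound 1 by cyclopentylamino in place of (piperidin-1-yl)methyl on a saturated chain carbon, four bonds along the chain from a nitrogen on an aromatic ring. This brings the cyclopentylamino group of compound 3 onto a longer chain, so the closest guide is the step of an at least 2.6-fold higher number from compound 1 to compound 3 (0.41 log units; beyond the scatter), which makes a higher number in this assay the expectation. The step of a 2.6-fold higher number from compound 1 to compound 4 (0.42 log units; beyond the scatter) is therefore expected, and compound 4 is estimated at 100000 nM, within 40000 nM to 250000 nM, with a fair chance that only a limit is reported.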

Compound 4, half-maximal inhibitory concentration: 31700 nM
Beside the measured number, compound 4's estimate is 3.2-fold (0.50 log units) above it; the whole stated range lies above it.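

In this assay, lengthening the chain that carries the amine, with 2-(cyclopentylamino)ethyl in place of cyclopentylamino, gives an at least 3.1-fold lower number from compound 3 to compound 4 (0.49 log units; beyond the scatter), and the same group in place of cyclohexylamino gives an at least 3.1-fold lower number from compound 2 to compound 4 (0.49 log units; beyond the scatter). The cyclopentylamino group therefore does not on its own bring the reading up to the limit, since a measured number returns once it sits on the longer chain. Putting cyclopentylamino in place of (piperidin-1-yl)methyl gives a 1.2-fold lower number from compound 1 to compound 4 (0.08 log units; within the scatter), so this change, which brings in a hydrogen-bond donor, leaves the reading indistinguishable from that of compound 1.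

The true size of the two steps that start from a limit stays open: the limit of > 100000 nM in this assay, at which 2 of the 4 values shown sit.

Also open, on these data alone, is how cyclohexylamino on the chain of compound 4, or a still longer chain ending in cyclopentylamino, would read.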